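The source may hold more compounds than are shown below. What is called first, only, known or untested is meant among the compounds shown, and "the series" means these compounds.

Measured compounds and their values:
compound 1, `Oc1nnc(-c2nc3ccccc3o2)o1`, 3 mg/kg
compound 2, `Cc1ccc2oc(-c3nnc(O)o3)nc2c1`, 2 mg/kg
compound 3, `Cn1c(-c2nnc(O)o2)nc2ccccc21`, 1 mg/kg

Of the compounds shown here, three have been tested in a functional assay on the whole organism for inhibition, with Rattus norvegicus as the target; a higher number here means that more compound is needed for the effect, a lower number that less compound is needed. Compound 1 and compound 2 share a core and differ in one place: methyl in place of hydrogen on an aromatic carbon. That change gave a 1.5-fold lower number from compound 1 to compound 2 (0.18 log units; within the scatter). Compound 3 rests on a different core; the difference between the two cores is not broken down here. In this assay compound 3 gives 1 mg/kg, the lowest of the three numbers, within the scatter of compound 2 and beyond the scatter of compound 1.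

Compound 4, `Cc1ccc2c(c1)nc(-c1nnc(O)o1)n2C`, has not yet been measured. It stands to compound 3 as compound 2 stands to compound 1: methyl in place of hydrogen on an aromatic carbon. The place lines of the two changes read the same word for word, so it is the same change made on the second core. For the measured compounds named here, the only guide to its size is the single measured step from compound 1 to compound 2, which lay within the scatter. The expected step is therefore small, a 1.4-fold lower number from compound 3 to compound 4 (0.15 log units; within the scatter), because the earlier one was a 1.5-fold lower number from compound 1 to compound 2 (0.18 log units; within the scatter). For compound 4 the estimate in this assay is 0.7 mg/kg, with a likely range from 0.3 mg/kg to 1.5 mg/kg.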

Compound 4, dose for half-maximal effect: 5 mg/kg
The estimate for compound 4 lay 7.1-fold (0.85 log units) below the measured number; the whole stated range lies below it.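

In this assay methyl in place of hydrogen on an aromatic carbon gave a 5.0-fold higher number from compound 3 to compound 4 (0.70 log units; beyond the scatter) on the core of compound 3. The step measured on the core of compound 1 therefore did not carry over to the core of compound 3, and the two cores answered this change differently: the same change on two cores in this assay, a 1.5-fold lower number (0.18 log units; within the scatter) from compound 1 to compound 2 and a 5.0-fold higher number (0.70 log units; beyond the scatter) from compound 3 to compound 4, 7.5-fold (0.88 log units) apart, beyond the scatter of two such steps. This shows that, in this series, the size and direction of the step on one core cannot simply be assumed for the other, but with a single pair on each core it does not show why the two steps part, nor whether any other change would fail to carry over in the same way.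

The compounds shown leave open how a larger or different group at this place, such as a chlorine atom, a methoxy group or a longer chain, would behave on either core. They also leave open whether such groups would separate the two cores as methyl does, or whether the gap belongs to methyl alone.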